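The source may report more compounds than this note shows. Statements on the series, on what has been measured and on what is new or still open speak of the compounds shown alone.

For the measured compounds named here, compound 2, with the structure `O=C(CNC(=O)c1cc2ccccc2cn1)OCc1ccccc1`, has the lower of the two numbers recorded for the two measured members of this small series. In a functional assay on the whole organism (CCRF S-180 cells, Mus musculus) for inhibition, in a xenograft, with stated times of 7 days and 24 h, at a dose of 100 umol/kg by the intraperitoneal route (a higher number here means more inhibition at the dose given (going by the name of the read-out), a lower number less inhibition), compound 2 gives 16.1%, the lowest of the two numbers recorded. Its nearest neighbour is compound 1, `CSCC[C@H](NC(=O)c1cc2ccccc2cn1)C(=O)OCc1ccccc1`, which in this assay gives 39.6%. Going by the values given here, the one measured step between them, a number 23.5 percentage points lower from compound 1 to compound 2 (beyond the scatter), shows that removing the 2-(methylsulfanyl)ethyl group from the saturated chain carbon bound to an amide-type nitrogen and a carbonyl carbon lowered the inhibition clearly.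

Compound 3, `O=C(N[C@@H](CO)C(=O)OCc1ccccc1)c1cc2ccccc2cn1`, returns a substituent to that same position: hydroxymethyl in place of hydrogen on a saturated chain carbon bound to an amide-type nitrogen and a carbonyl carbon. Among the compounds with values here, the only step that bears on this change is the one from compound 1 to compound 2, and it ran in the opposite direction with a modest size. A hydroxymethyl group is, however, not the same as a 2-(methylsulfanyl)ethyl group, so only part of that recovery is expected. For compound 3 in this assay the expected step from compound 2 is a number 11.9 percentage points higher from compound 2 to compound 3 (beyond the scatter), and the estimated inhibition of compound 3 is 28%, with a range from 10% to 48%.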

Compound 3, a percentage reported as inhibition, in the whole organism at one dose (the size of the read-out at that dose, not a potency): 40.4%
Beside the measured number, compound 3's estimate is 12.4 percentage points below it, and the stated range covers the measured number.
By their numbers in this assay, from the lowest: compound 2; then compounds 1 and 3 (each within the scatter of the next).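

In this assay, placing hydroxymethyl on the saturated chain carbon bound to an amide-type nitrogen and a carbonyl carbon gives a number 24.3 percentage points higher from compound 2 to compound 3 (beyond the scatter). The earlier compounds had shown the effect of a substituent at this position with 2-(methylsulfanyl)ethyl alone; this step shows it with a second, different group. The two substituted compounds are not separated by this read-out, since hydroxy in place of (methylsulfanyl)methyl gives a number 0.8 percentage points higher from compound 1 to compound 3 (within the scatter), so among these three compounds the hydrogen of compound 2 is what stands apart, and the gain does not depend on which of these two groups is present. No measurement offered here accounts for this result, so the reason for it remains unknown.

The compounds shown leave open whether a plain methyl group, with no hydroxy or sulfur atom, would give the same gain over hydrogen. They also leave open how an aminomethyl group, a carboxylic acid or a longer alkyl chain would read at this position in this assay.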